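A few compounds are considered here, and "the series" means these few. Any claim that something is new, unique, unknown or untested is made for them only; others in the source may bear on it.

Measured so far in a physicochemical assay for solubility, read by nephelometry, measured as kinetic solubility, at pH 2.0; on this read-out lower numbers stand for lower solubility and higher numbers for higher solubility:
Compound 1 `NCc1csc(NC(=O)c2ccc(Cl)cc2)n1`: > 100 ug/mL (a limit, not a number)
Compound 2 `COc1ccc(C(=O)Nc2nc(CN)cs2)cc1`: 50 ug/mL

In this assay, among the compounds with values here, compound 2 gives 50 ug/mL, the only exact number so far. Compound 1 reads > 100 ug/mL, which is a limit of the assay and not an exact number. Within the data shown here, the one measured step, an at least 2.0-fold lower number from compound 1 to compound 2 (0.30 log units; that floor lies within the scatter), puts methoxy in place of chloro on an aromatic carbon, and its size is known only as a floor.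

Compound 3 `NCc1csc(NC(=O)c2ccccc2)n1` changes that same place again: hydrogen in place of methoxy on an aromatic carbon. This is hydrogen in place of methoxy on an aromatic carbon, para to a large group. Among the measured compounds shown here, no step to hydrogen has been measured, so the only guide is the earlier swap at this place, and it gives no firm size. Methoxy arrived with an at least 2.0-fold lower number from compound 1 to compound 2 (0.30 log units; that floor lies within the scatter), so removing it is expected to lean, if anything, towards a higher number. No change beyond the scatter is expected, and the estimated step is a 1.4-fold higher number from compound 2 to compound 3 (0.15 log units; within the scatter). Compound 3 is expected at 70 ug/mL, with an estimated range from 30 ug/mL to 130 ug/mL.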

Compound 3, solubility: > 100 ug/mL
Compound 3: only a limit was reported (the forecaster's own chance of this, stated with the estimate: 30%); middle value at least 1.4-fold (0.15 log units) from the limit.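

In this assay compound 3 gives > 100 ug/mL, which is a limit of the assay and not a number. Within the data shown here, replacing methoxy with plain hydrogen at this place on the aromatic ring gives an at least 2.0-fold higher number from compound 2 to compound 3 (0.30 log units; that floor lies within the scatter), so methoxy is now the only one of the three groups tried here that gives an exact number, while chloro and hydrogen both end at a limit, though this floor alone does not carry the change beyond the usual scatter. The step between compound 1 and compound 3, which swaps chloro for hydrogen, cannot be read, because both values are limits: the limit of > 100 ug/mL in this assay, at which 2 of the 3 values shown sit.

From the compounds shown here alone, it remains open how far compound 1 and compound 3 truly lie from compound 2, and so whether removing methoxy makes a real difference or one that repeat measurements could not separate from scatter. No group other than chloro, methoxy and hydrogen has been measured at this place. Going by these compounds, it is also open whether a different group there, such as an ethoxy group, a nitrile or a carboxylic acid, would give an exact number.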